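A benzyl-for-tolyl swap, made on two different sulfurs

The source may hold more compounds than are shown below. What is called first, only, known or untested is meant among the compounds shown, and "the series" means these compounds.

Compound 2 `COc1ccccc1/C=C(\C(=O)c1ccc(Cl)cc1)S(=O)(=O)c1ccc(C)cc1` and compound 1 `COc1ccccc1/C=C(\C(=O)c1ccc(Cl)cc1)S(=O)(=O)Cc1ccc(Cl)c(Cl)c1` differ in one place: 3,4-dichlorobenzyl in place of 4-methylphenyl on a sulfonyl sulfur. In a functional assay on DU-145 cells (Homo sapiens) for inhibition, read by trypan blue exclusion, with a stated time of 96 h (a lower number here means a stronger inhibitor of growth, a higher number a weaker inhibitor of growth), compound 2 gives 1000 nM, and compound 1 gives 1000 nM, so the step of no change at the digits printed from compound 2 to compound 1 (within the scatter) is flat.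

Compound 3 `Cc1ccc(S/C(=C/c2c(O)cc(O)cc2O)C(=O)c2ccc(Cl)cc2)cc1` belongs to a second core; how it differs from compound 2 is not broken down here. Compound 3 in this assay reaches only a limit of the assay, > 100000 nM. That limit is the one at the limit of > 100000 nM in this assay, at which 1 of the 3 values shown sits.

Compound 4 `O=C(/C(=C\c1c(O)cc(O)cc1O)SCc1ccc(Cl)c(Cl)c1)c1ccc(Cl)cc1` is not yet measured. It stands to compound 3 as compound 1 stands to compound 2: 3,4-dichlorobenzyl in place of 4-methylphenyl on a sulfur. The two surroundings are not identical, since in the first pair the change sits on a sulfonyl sulfur whose other neighbour is a double-bonded chain carbon, whereas here it sits on a sulfur whose other neighbour is a double-bonded chain carbon, so this is the same kind of change rather than the same change. Because the measured step of no change at the digits printed from compound 2 to compound 1 (within the scatter) is flat, the step of a number no higher from compound 3 to compound 4 (the limit leaves the size open) is expected to be flat as well, leaving compound 4 where compound 3 stands. Compound 4 is therefore estimated to come out at 100000 nM in this assay, most likely again reported only as a limit.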

Compound 4, concentration for 50% growth inhibition: 25000 nM
Estimate against measurement, compound 4: 4.0-fold (0.60 log units) above, outside the stated range (below it).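

In this assay, putting 3,4-dichlorobenzyl in place of 4-methylphenyl on a sulfur gave an at least 4.0-fold lower number from compound 3 to compound 4 (0.60 log units; beyond the scatter), so the flat result seen on the sulfonyl sulfur did not carry over to the second core. Set side by side, the two steps differ: the same change on two cores in this assay, no change at the digits printed (within the scatter) from compound 2 to compound 1 and an at least 4.0-fold lower number (0.60 log units; beyond the scatter) from compound 3 to compound 4, at least 4.0-fold (0.60 log units) apart, beyond the scatter of two such steps For compound 3 the reading of > 100000 nM is a limit of the assay and not a number, so the size of the new step stays open, and a single pair on each core does not show which difference between the two cores goes with the different outcome.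

The compounds shown leave open whether a plain benzyl, a longer alkyl chain or a benzyl carrying an amine would follow compound 4 in place of the 3,4-dichlorobenzyl group. They also leave open whether the same swap would give a step of this kind on other cores in the series.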